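Swapping methyl for chloro on a weak inhibitor series

This account rests on a few compounds, and the source may have more. Where it says the series, first, only, none or still open, it means among the compounds named here.

Of the compounds shown here, three of a shared core have been measured in an assay on isolated protein for inhibition of Amine oxidase [flavin-containing] B (Homo sapiens), read by fluorescence, with stated times of 15 min and 20 min; a lower number here means a stronger inhibitor, a higher number a weaker inhibitor. Compound 1 `Cc1ccc(C2=NN(C(=O)CN3CCCCC3)C(c3ccccc3O)C2)cc1` gives 45600 nM in this assay. Compound 2 `O=C(CN1CCCCC1)N1N=C(c2ccc(Cl)cc2)CC1c1ccccc1O` gives 40100 nM in this assay. Compound 3 `Cc1ccc(C2=NN(C(=O)CN3CCCCC3)C(c3cc(Cl)ccc3O)C2)cc1` gives 56200 nM in this assay, which is the highest of the three numbers, though its gap to compound 1 and to compound 2 lies within the scatter, so all three count as about equally weak inhibitors.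

Compound 4 `O=C(CN1CCCCC1)N1N=C(c2ccc(Cl)cc2)CC1c1cc(Cl)ccc1O` has not yet been measured. It differs from compound 3 in one place: chloro in place of methyl on an aromatic carbon. The same exchange has been seen once before in this set, between compound 1 and compound 2, where it produced a 1.1-fold lower number from compound 1 to compound 2 (0.06 log units; within the scatter). The other measured step, a 1.2-fold higher number from compound 1 to compound 3 (0.09 log units; within the scatter), concerns a different position and only confirms that small changes on this core have moved the number little so far.

On that basis, no shift beyond the scatter is expected from compound 3 to compound 4 in this assay, that is, a step of a 1.1-fold lower number from compound 3 to compound 4 (0.05 log units; within the scatter). Compound 4 is therefore estimated to give 50000 nM in this assay, with a range from 25000 nM to 100000 nM.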

Compound 4, half-maximal inhibitory concentration: 44100 nM
For compound 4 the middle estimate is 1.1-fold (0.05 log units) above the measured one; the measured number falls inside the stated range.
By their numbers in this assay, from the lowest: compounds 2, 4, 1 and 3 (each within the scatter of the next).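

In this assay, the change from 4-methylphenyl to 4-chlorophenyl gives a 1.3-fold lower number from compound 3 to compound 4 (0.11 log units; within the scatter). This exchange has now been read on two cores, and both times the step stays small: the same change on two cores in this assay, a 1.1-fold lower number (0.06 log units; within the scatter) from compound 1 to compound 2 and a 1.3-fold lower number (0.11 log units; within the scatter) from compound 3 to compound 4, 1.1-fold (0.05 log units) apart, within the scatter of two such steps. The other exchange, chloro in place of hydrogen on an aromatic carbon, can now also be read a second time, as a 1.1-fold higher number from compound 2 to compound 4 (0.04 log units; within the scatter), and it repeats in the same way: the same change on two cores in this assay, a 1.2-fold higher number (0.09 log units; within the scatter) from compound 1 to compound 3 and a 1.1-fold higher number (0.04 log units; within the scatter) from compound 2 to compound 4, 1.1-fold (0.05 log units) apart, within the scatter of two such steps. Together, these four compounds show that neither exchange moves the number beyond the scatter, whether or not the other one is present, so the two changes can be combined here without any departure from what each shows alone.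

The compounds shown carry only methyl or chloro at this position, two groups of one heavy atom each, so they say nothing about how a longer chain, an amine or a carboxylic acid would behave there. On these data alone, it also remains open whether any change at this position can lift these weak inhibitors clear of the scatter.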